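A benzotriazole in place of benzylamine on the urea

The source may report more compounds than this note shows. Statements on the series, on what has been measured and on what is new or still open speak of the compounds shown alone.

Compounds measured so far:
- compound 1, `COc1cc(NC(C)CCCNC(=O)NC(c2ccccc2)c2ccccc2)c2ncccc2c1`; in an ADME assay on HEL cells (Homo sapiens) for cytotoxicity (on this read-out higher numbers stand for lower toxicity in this test and lower numbers for higher toxicity in this test), compound 1 reaches only the assay limit of > 100000 nM.
- compound 2, `COc1cc(NC(C)CCCNC(=O)NCc2ccccc2)c2ncccc2c1`; in this assay compound 2 gives 100000 nM.

Among the measured compounds shown here, compound 2 holds the only actual number in this set; the other value is a limit rather than a number. For the measured compounds named here, the single measured step, a number no higher from compound 1 to compound 2 (the limit leaves the size open), sits at the boundary of the assay, as the limit of > 100000 nM in this assay, at which 1 of the 2 values shown sits, shows, so its true size cannot be read.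

Compound 3, `COc1cc(NC(C)CCCNC(=O)n2nnc3ccccc32)c2ncccc2c1`, differs from compound 2 by a group of 9 heavy atoms (6 carbon, 3 nitrogen; one five-membered aromatic ring with 3 hetero atoms, one six-membered aromatic ring of carbon only) in place of a group of 8 heavy atoms (7 carbon, 1 nitrogen; one six-membered aromatic ring of carbon only), on a carbonyl carbon. Going by the values given here, no measured step involves this part of the molecule, so no direction beyond the scatter is expected. Compound 3 is therefore estimated at 100000 nM, with a range from 50000 nM to 200000 nM, which means an expected step of no change at the digits printed from compound 2 to compound 3 (within the scatter), while a limit instead of a number is quite possible.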

Compound 3, minimum cytotoxic concentration: > 100000 nM
Compound 3 was reported as a limit; the forecaster's own chance of this, stated with the estimate: 50%; the middle value lies on the limit itself.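

On the carbonyl carbon, the benzotriazole replaces benzylamino, exchanging a group with 1 hydrogen-bond donor and 0 acceptors for one with 0 donors and 3 acceptors, and this gives a number no lower from compound 2 to compound 3 (the limit leaves the size open) in this assay. Compound 3 gives > 100000 nM, which is a limit of the assay and not a number. This is the first measured change at this position, and it brings no lower number in this test, but neither step's size can be read because so many values are limits: the limit of > 100000 nM in this assay, at which 2 of the 3 values shown sit.

The compounds shown leave open whether a simple amine or a methoxy group on this carbonyl carbon would give a lower number than compound 2. They also leave open whether a longer chain in the linker would change the read-out.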